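Azido in place of methoxy on the shared core

The source may hold more compounds than are shown below. What is called first, only, known or untested is meant among the compounds shown, and "the series" means these compounds.

Compound 3 `COc1c(F)c(N)c2c(=O)cc(-c3ccc(N)c(F)c3)oc2c1F` stands with the lowest number of the two given in a functional assay on MCF7 cells (Homo sapiens) for cytotoxicity, read by neutral red uptake, with a stated time of 3 days (a higher number here means a weaker inhibitor, a lower number a stronger inhibitor), where compound 3 gives 100 nM. Its nearest neighbour is compound 1 `CCc1c(F)c(N)c2c(=O)cc(-c3ccc(N)c(F)c3)oc2c1F`, and in this assay compound 1 gives 130 nM; the two values lie within the scatter. Compound 2 `CCCCCCc1c(F)c(N)c2c(=O)cc(-c3ccc(N)c(F)c3)oc2c1F` reports only a limit in this assay, > 10000 nM, and not a number. That limit is the limit of > 10000 nM in this assay, at which 1 of the 3 values shown sits. The measured steps run as follows: a 1.3-fold lower number from compound 1 to compound 3 (0.11 log units; within the scatter); an at least 76-fold higher number from compound 1 to compound 2 (1.88 log units; beyond the scatter); an at least 100-fold lower number from compound 2 to compound 3 (2.00 log units; beyond the scatter). Compound 4 `[N-]=[N+]=Nc1c(F)c(N)c2c(=O)cc(-c3ccc(N)c(F)c3)oc2c1F` differs from compound 3 by azido in place of methoxy on an aromatic carbon. Among the measured compounds shown here, the step that bears most directly on this change is the one from compound 1 to compound 3, where ethyl and methoxy at this carbon give numbers within the scatter of each other; the two large steps both involve hexyl, not a group of two or three heavy atoms as here. A step of the size seen for hexyl is therefore not expected; the expected step is a 1.5-fold higher number from compound 3 to compound 4 (0.18 log units; within the scatter). For compound 4 the estimate is 150 nM, with a range from 50 nM to 600 nM.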

Compound 4, half-maximal inhibitory concentration: 460 nM
Compound 4: the middle estimate sits 3.1-fold (0.49 log units) below what was measured; the range from low to high includes it.
By their numbers in this assay, from the lowest: compounds 3 and 1 (each within the scatter of the next); then compound 4. At a limit, above all of these: compound 2.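

In this assay, azido on this aromatic carbon stands apart from both small groups, with a 4.6-fold higher number from compound 3 to compound 4 (0.66 log units; beyond the scatter) and a 3.5-fold higher number from compound 1 to compound 4 (0.55 log units; beyond the scatter), whereas ethyl and methoxy here gave numbers within the scatter of each other. The position therefore responds to a change among small groups as well as to hexyl, although these steps are modest and the step from hexyl remains large, at an at least 21-fold lower number from compound 2 to compound 4 (1.33 log units; beyond the scatter). Compound 2 gives only a limit in this assay, not a number: the limit of > 10000 nM in this assay, at which 1 of the 4 values shown sits.

The four groups shown leave open whether the higher number belongs to azido alone or would also appear with other nitrogen groups on this carbon, such as an amine. They also leave open where along the chain the large step begins, which a butyl chain would help to place.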